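This account rests on a few compounds, and the source may have more. Where it says the series, first, only, none or still open, it means among the compounds named here.

The measured compounds:

Compound 1, `CN1CCC[C@H](OCc2cc(Cl)cc(Cl)c2)[C@@H]1c1ccccc1`, in an assay on isolated protein for activation of cGMP-dependent protein kinase 1 (Homo sapiens), read by ADP-Glo, with stated times of 120 min and 40 min (a higher number here means that more compound is needed for the effect, a lower number that less compound is needed), compound 1 gives only a limit, > 200000 nM.
Compound 2, `OC[C@@H](O[C@H]1CCCN(Cc2ncc[nH]2)[C@H]1c1ccccc1)c1cc(Cl)cc(Cl)c1`, in this assay compound 2 gives 7000 nM.
Compound 3, `Clc1cc(Cl)cc(CO[C@H]2CCCN(Cc3nccs3)[C@H]2c2ccccc2)c1`, in this assay compound 3 gives only a limit, > 200000 nM.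

Compound 3 thus stands at a limit, not at a number, and the same holds for compound 1 (the limit of > 200000 nM in this assay, at which 2 of the 3 values shown sit). Going by the values given here, the one step among the measured compounds that touches compound 3, a step that the two limits leave unreadable from compound 1 to compound 3, cannot be read because both ends are limits, so no measured step tells how large a change on this part of the molecule is.

Compound 4, `Clc1cc(Cl)cc(CO[C@H]2CCCN(Cc3ncc[nH]3)[C@H]2c2ccccc2)c1`, differs from compound 3 in one place: 1H-imidazol-2-yl in place of 1,3-thiazol-2-yl on a saturated chain carbon bound to an amine nitrogen in a ring. Among the compounds with values here, compound 2 also carries the imidazolyl group and gives a number rather than a limit, which is the only hint that this group may bring compound 4 within the range of this assay. The step of an at least 5.0-fold lower number from compound 3 to compound 4 (0.69 log units; beyond the scatter) is therefore expected to move toward less compound needed, with wide uncertainty. Compound 4 is estimated at 40000 nM, with a range from 5000 nM to 200000 nM.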

Compound 4, half-maximal effective concentration: 47000 nM
Beside the measured number, compound 4's estimate is 1.2-fold (0.07 log units) below it; low and high end bracket the measured number.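

Going by these compounds alone, replacing (1,3-thiazol-2-yl)methyl with (1H-imidazol-2-yl)methyl gives the first change at this place that can be sized in this assay, as an at least 4.2-fold lower number from compound 3 to compound 4 (0.62 log units; beyond the scatter) shows, while 1H-imidazol-2-yl in place of hydrogen gives an at least 4.2-fold lower number from compound 1 to compound 4 (0.62 log units; beyond the scatter) at the same carbon. Both sizes are only minimum sizes because each starting compound sits at a limit: the limit of > 200000 nM in this assay, at which 2 of the 4 values shown sit. The imidazolyl group alone does not reach the level of compound 2, since hydrogen in place of hydroxymethyl gives a 6.7-fold higher number from compound 2 to compound 4 (0.83 log units; beyond the scatter), so the group on the other side of the ether oxygen matters too.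

As far as these compounds go, it remains open whether the hydrogen on the imidazole nitrogen matters, which a 1-methylimidazol-2-yl group could test. From the compounds shown here alone, how an aminomethyl group or a longer chain would compare with hydroxymethyl at its place also remains open.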